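Removing a Methyl from an Inactive Anilide Series

This account rests on a few compounds, and the source may have more. Where it says the series, first, only, none or still open, it means among the compounds named here.

Of the compounds shown here, three sharing one core have been tested in an ADME assay on HCT-116 cells (Homo sapiens) for cytotoxicity, read by MTT assay, with a stated time of 72 h; a lower number here means a stronger inhibitor, a higher number a weaker inhibitor. Compound 1 `Cc1ccc(NC(=O)c2cccc(/C=C3\CC(=O)N(c4ccccc4)C3=O)c2)cc1` gives only > 100000 nM, which is a limit of the assay and not a number. Compound 2 `O=C(Nc1ccccc1)c1cccc(/C=C2\CC(=O)N(c3ccccc3)C2=O)c1` likewise gives only the limit > 100000 nM. Compound 3 `Cc1ccc(NC(=O)c2cccc(/C=C3\CC(=O)N(c4ccccc4)C3=O)c2)cc1C` also stops at the limit > 100000 nM. Compound 3 therefore stands nowhere distinct: all three values sit at the same limit, as the limit of > 100000 nM in this assay, at which 3 of the 3 values shown sit, records, so no ordering among them can be read.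

The steps between the measured compounds are all unreadable for the same reason. a step that the two limits leave unreadable from compound 1 to compound 2, a step that the two limits leave unreadable from compound 1 to compound 3 and a step that the two limits leave unreadable from compound 2 to compound 3 each run between two limits, so their size is unknown.

The unmeasured compound 4 `Cc1cccc(NC(=O)c2cccc(/C=C3\CC(=O)N(c4ccccc4)C3=O)c2)c1` differs from compound 3 by a single change: hydrogen in place of methyl on an aromatic carbon. The closest measured comparison, the loss of an aromatic methyl between compound 1 and compound 2, also lies between limits. Nothing in the measured steps points to a gain in potency, so the expected change is a step that the limit leaves unreadable from compound 3 to compound 4, most likely ending again at the limit. Compound 4 is therefore estimated at 150000 nM, with a range from 60000 nM to 500000 nM.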

Compound 4, half-maximal inhibitory concentration: > 100000 nM
Compound 4: a limit, no number; the forecaster's own chance of this, stated with the estimate: 85%; the middle value does not contradict the limit.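

In this assay compound 4 gives > 100000 nM, which is a limit of the assay and not a number. Within the data shown here, no step between compound 4 and compound 1, compound 2 or compound 3 can be read, because all four compounds stop at the same limit: the limit of > 100000 nM in this assay, at which 4 of the 4 values shown sit. The compounds shown leave open whether any methyl change alters the true values in this assay.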